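Adding a methoxy to compound 3

The source may hold more compounds than are shown below. What is called first, only, known or untested is meant among the compounds shown, and "the series" means these compounds.

- compound 1 `COc1ccc(C(C)=O)cc1COc1cccc(C)c1` gives 2800 nM
- compound 2 `CCc1ccc(OC)c(COc2ccc(Cl)c(C)c2)c1` gives 40000 nM
- compound 3 `COc1ccc(C(N)=O)cc1/C=C/c1ccccc1` gives 2400 nM

In a functional assay on HUVEC cells (Homo sapiens) for inhibition, with a stated time of 4 days (on this read-out higher numbers stand for weaker inhibition and lower numbers for stronger inhibition), compound 3 and compound 1 cannot be told apart, as their numbers lie within the usual scatter of each other. Compound 2 has a clearly higher number than compound 3 and so inhibits more weakly.

Compound 4 `COc1ccc(/C=C/c2cc(C(N)=O)ccc2OC)cc1` differs from compound 3 by one change: methoxy in place of hydrogen on an aromatic carbon. Going by the values given here, no measured pair shows what this change does, so any forecast is uncertain. A modest move toward stronger inhibition is expected, estimated as a 2.4-fold lower number from compound 3 to compound 4 (0.38 log units; beyond the scatter) in this assay overall. For compound 4 the expected value is 1000 nM, with 150 nM to 6000 nM as the estimated range.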

Compound 4, half-maximal inhibitory concentration: 8800 nM
Compound 4: the middle estimate sits 8.8-fold (0.94 log units) below what was measured, and the stated range ends below it.
By their numbers in this assay, from the lowest: compounds 3 and 1 (each within the scatter of the next); then compound 4; then compound 2.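

In this assay, methoxy in place of hydrogen on an aromatic carbon, para to a large group, gives a 3.7-fold higher number from compound 3 to compound 4 (0.56 log units; beyond the scatter) and so weakens inhibition beyond the scatter. Going by these compounds alone, this is the first single-change pair, and it shows that this position does not simply accept the added methoxy. Nothing measured here explains the rise.

The compounds shown leave open whether a hydroxyl or a fluorine atom at this position would also raise the number. They also leave open whether methoxy on another carbon of this ring would do the same.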